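The source may hold more compounds than are shown below. What is called first, only, known or untested is meant among the compounds shown, and "the series" means these compounds.

Working notes on the thiosemicarbazide series.

Among the compounds with values here, compound 1 `N/C(=N\NC(=S)N1CCOCC1)c1ccccn1` is the lower of the two compounds measured so far. In a functional assay on A-375 cells (Homo sapiens) for cytotoxicity, read by MTT assay, with a stated time of 72 h, tested at 1 uM (on this read-out lower numbers stand for less inhibition of growth and higher numbers for more inhibition of growth at the one concentration tested), compound 1 gives 26.8%. Compound 2 `N/C(=N\NC(=S)N1CCN(c2ccccn2)CC1)c1ccc(F)cn1` differs from compound 1 in more than one place, so no single step can be read between them; in this assay compound 2 gives 49.3%, a number that lies beyond the scatter above that of compound 1, but which part of the structural difference carries it cannot be told from these two compounds alone.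

Compound 3 `Cc1ccnc(/C(N)=N/NC(=S)N2CCOCC2)c1` is the next compound to be measured. It differs from compound 1 in one place only: methyl in place of hydrogen on an aromatic carbon. Within the data shown here, no step between measured compounds of this kind exists, so there is no measured precedent for it. A change of this small size, a single carbon added on the ring that carries no other change, is expected to move the read-out little, most likely not beyond the scatter, with the direction uncertain and a slight upward lean at most.

Compound 3 is therefore expected to fall near compound 1, with a step of a number 3.2 percentage points higher from compound 1 to compound 3 (within the scatter) that is estimated to stay within the scatter.

For compound 3 the expected value in this assay is 30%, estimated to fall between 15% and 48%.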

Compound 3, percent growth inhibition at one concentration: 43.2%
Compound 3: the middle estimate sits 13.2 percentage points below what was measured, and the stated range covers the measured number.
By their numbers in this assay, from the lowest: compound 1; then compounds 3 and 2 (each within the scatter of the next).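

In this assay, within the data shown here, adding a single methyl on an aromatic carbon of the six-membered aromatic ring with 1 nitrogen, meta to a large group and opposite the ring nitrogen, gives the first step that can be read at one place: a number 16.4 percentage points higher from compound 1 to compound 3 (beyond the scatter) and with the rest of compound 1 unchanged. This position is therefore not silent, since the addition of 1 carbon here is enough to move the growth inhibition at the one tested concentration upward beyond the scatter, though one step gives a direction for methyl only and no trend. No measured information bears on why the step occurs.

Going by these compounds, it remains open whether other groups at this position, such as ethyl, methoxy, chlorine or an amine, would move the read-out in the same direction or by a similar amount. Also open, on these data alone, is whether methyl on another aromatic carbon of this ring would give a comparable step, and whether this methyl would do so on the core of compound 2.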